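This account rests on a few compounds, and the source may have more. Where it says the series, first, only, none or still open, it means among the compounds named here.

Compound 1 `C=CC[C@@H]1CN[C@H](C(=O)N2CCC[C@H]2C#N)C1` and compound 2 `N#C[C@@H]1CCCN1C(=O)[C@@H]1C[C@H](CCO)CN1` share a core and differ only in one side group. In an assay on the whole organism (plasma, strain Sprague-Dawley) for inhibition of Dipeptidyl peptidase 4 (Rattus norvegicus), with a stated time of 6 h, at a dose of 1 mg/kg by the oral route (a higher number here means more inhibition at the dose given (going by the name of the read-out), a lower number less inhibition), compound 1 gives 38%, while compound 2 gives 64%, which is the higher of the two numbers. That single change gave a number 26 percentage points higher from compound 1 to compound 2 (beyond the scatter), a step beyond the usual scatter. Compound 3 `N#C[C@@H]1CCCN1C(=O)[C@@H]1CCCN1` is not yet measured. The change from compound 2 to compound 3 is hydrogen in place of 2-hydroxyethyl on a saturated ring carbon, so the side chain is removed altogether rather than swapped. Going by the values given here, the one measured step bears on it only loosely, since it compares two different chains rather than a chain against none, but it shows that this position does move the read-out in this assay by a modest amount. For compound 3 a decrease is expected, with an estimated step of a number 24 percentage points lower from compound 2 to compound 3 (beyond the scatter), placing compound 3 at about 40% with a likely range of 15% to 65% in this assay.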

Compound 3, a percentage reported as inhibition, in the whole organism at one dose (the size of the read-out at that dose, not a potency): 20%
The estimate for compound 3 lay 20 percentage points above the measured number, within the range that was stated.
By their numbers in this assay, from the lowest: compound 3; then compound 1; then compound 2.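

Going by these compounds alone, compound 3 carries only hydrogen at this ring carbon, so it gives the first reading of the position with no side chain at all. In this assay, removing the 2-hydroxyethyl chain gives a number 44 percentage points lower from compound 2 to compound 3 (beyond the scatter), and removing the allyl chain gives a number 18 percentage points lower from compound 1 to compound 3 (beyond the scatter), so among these three compounds either chain goes with more inhibition at the dose given than hydrogen does. No measurement shown explains why the number falls when the chain is removed.

As far as these compounds go, whether a 2-aminoethyl chain, a carboxylic acid or a longer chain such as 3-hydroxypropyl at this ring carbon would give a higher or lower number than 2-hydroxyethyl remains open. A single reading at one dose and time also leaves open whether these differences reflect inhibition of the enzyme itself or how much of each compound reaches the plasma.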